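The compounds below may be only part of what the source reports. "The series", "measured", "known", "first", "only" and "open" are said of these compounds alone.

In an in vivo ADME assay on the whole organism (strain Swiss) for pharmacokinetics, with Mus musculus as the target, read by LC-MS, at a dose of 2.5 mg/kg by the intravenous route (a lower number here means that more of the compound stays in the plasma, a higher number that more of the compound sits outside the plasma), compound 1 `Nc1ncnc2c1nc(Sc1cc3c(cc1Br)OCCO3)n2CCC1CCN(C=O)CC1` gives 1.05 L/kg and compound 2 `C[C@H](O)C(=O)N1CCC(CCn2c(Sc3cc4c(cc3Br)OCCO4)nc3c(N)ncnc32)CC1` gives 1.07 L/kg with the two level within the scatter. Compound 3 `C[C@@H](O)C(=O)N1CCC(CCn2c(Sc3cc4c(cc3Br)OCCO4)nc3c(N)ncnc32)CC1` differs from compound 2 in configuration only (the two compounds have the same atoms and bonds and differ only in configuration as drawn: 1 of 1 stereo elements differ; a stereocentre at a saturated chain carbon is drawn S in compound 2 and R in compound 3). Among the measured compounds shown here, the one measured step that bears on this came with 1-hydroxyethyl in place of hydrogen on a carbonyl carbon. For the measured compounds named here, with a 1.0-fold higher number from compound 1 to compound 2 (0.01 log units; within the scatter) as the only guide and no measured pair testing configuration itself, no shift beyond the scatter is expected. The expected step is therefore small (a 1.0-fold lower number from compound 2 to compound 3 (0.01 log units; within the scatter)). Compound 3 is estimated at 1.05 L/kg (expected range 0.7 L/kg to 1.6 L/kg).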

Compound 3, volume of distribution: 1.35 L/kg
For compound 3 the middle estimate is 1.3-fold (0.11 log units) below the measured one; measured number inside the range.
By their numbers in this assay, from the lowest: compounds 1, 2 and 3 (each within the scatter of the next).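

Among the compounds shown here, changing the stereocentre at the saturated chain carbon from S to R in this assay gives a step that stays within the scatter (a 1.3-fold higher number from compound 2 to compound 3 (0.10 log units; within the scatter)), so this is the first test of configuration at this position, and it shows no clear effect. Compound 3, with the R form of 1-hydroxyethyl in place of hydrogen on the carbonyl carbon, also stays within the scatter of compound 1 (a 1.3-fold higher number from compound 1 to compound 3 (0.11 log units; within the scatter)). The comparison of compounds 2 and 3 isolates configuration: the fact that compounds 2 and 3 differ only in the configuration as drawn. Still open, from the compounds shown here alone, is whether an amine, a carboxylic acid or a longer chain at this carbonyl carbon would move the volume of distribution beyond the scatter.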